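Shortening the Amine Chain of Compound 2

The source may report more compounds than this note shows. Statements on the series, on what has been measured and on what is new or still open speak of the compounds shown alone.

In an assay for inhibition of beta-galactosidase (Homo sapiens), read by fluorescence, with a stated time of 30 min, at pH 4.5 (a higher number here means a weaker inhibitor, a lower number a stronger inhibitor), compound 2 `CCCCCCCCN[C@@H]1C=C[C@H](O)[C@H](O)[C@H]1O` gives 120000 nM, the highest of the two numbers recorded so far. Among the compounds with values here, the only other measured compound, compound 1 `CCCCCCCCN[C@@H]1C=C(C)[C@H](O)[C@H](O)[C@H]1O`, gives 46000 nM in this assay, and the step of a 2.6-fold higher number from compound 1 to compound 2 (0.42 log units; beyond the scatter) came with hydrogen in place of methyl on a double-bonded ring carbon. Compound 3 `CCCCN[C@@H]1C=C[C@H](O)[C@H](O)[C@H]1O` changes compound 2 elsewhere: hydrogen in place of butyl on a saturated chain carbon, four bonds along the chain from an amine nitrogen. Neither measured step touches the chain on the amine nitrogen, so the two values in hand offer no guide to the size or direction of this change, and any expectation must be held loosely. A modest step upward, that is a somewhat weaker inhibitor, is expected as a 1.7-fold higher number from compound 2 to compound 3 (0.22 log units; within the scatter), with a wide range on either side. Compound 3 is therefore estimated to give 200000 nM in this assay, within a range of 50000 nM to 1000000 nM.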

Compound 3, half-maximal inhibitory concentration: 50000 nM
For compound 3 the middle estimate is 4.0-fold (0.60 log units) above the measured one; measured number inside the range.
By their numbers in this assay, from the lowest: compounds 1 and 3 (each within the scatter of the next); then compound 2.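

In this assay hydrogen in place of butyl, four bonds along the chain from an amine nitrogen, brings a 2.4-fold lower number from compound 2 to compound 3 (0.38 log units; beyond the scatter) and so gives the stronger inhibitor of this pair. Within the data shown here, this is the first measured change to the chain on the amine nitrogen, and it shows that shortening this chain need not cost inhibition: here a shorter chain goes with a lower number, by a modest step. No supporting measurement is available to explain the change, so its reason remains unknown.

Going by these compounds, it remains open whether a still shorter chain, such as ethyl, or a chain ending in a carboxylic acid would lower the number further. Also open, on these data alone, is how the butyl chain of compound 3 would behave with the methyl on the double-bonded ring carbon of compound 1.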